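The source may report more compounds than this note shows. Statements on the series, on what has been measured and on what is new or still open speak of the compounds shown alone.

In a functional assay on A549 cells (Homo sapiens) for cytotoxicity, read by MTT assay, with a stated time of 72 h (a higher number here means a weaker inhibitor, a lower number a stronger inhibitor), compound 2 `O=C(Nc1ccc(Oc2ccnc3[nH]ccc23)cc1)c1cc(-c2ccccc2)ccn1` gives 2920 nM. Compound 1 `Cc1cccc(-c2ccnc(C(=O)Nc3ccc(Oc4ccnc5[nH]ccc45)cc3)c2)c1` differs from it by methyl in place of hydrogen on an aromatic carbon and gives 7010 nM in this assay; the step of a 2.4-fold higher number from compound 2 to compound 1 (0.38 log units; beyond the scatter) made the number higher. Compound 3 `O=C(Nc1ccc(Oc2ccnc3[nH]ccc23)c(F)c1)c1ccc(-c2ccccc2)cn1` gives 1250 nM in this assay; the difference between the core of compound 3 and the core of compound 2 is not broken down here. Compound 4 `Cc1ccc(-c2ccc(C(=O)Nc3ccc(Oc4ccnc5[nH]ccc45)c(F)c3)nc2)cc1` is not yet measured in this assay; it differs from compound 3 by methyl in place of hydrogen on an aromatic carbon. Among the compounds with values here, this is the same kind of change as the one from compound 2 to compound 1, but not the same: in compound 1 the methyl sits meta to a large group, in compound 4 para to a large group. An expected step of a 1.8-fold higher number from compound 3 to compound 4 (0.26 log units; within the scatter) rests on the earlier step of a 2.4-fold higher number from compound 2 to compound 1 (0.38 log units; beyond the scatter), with compound 3 giving 1250 nM. For compound 4 a value of 2300 nM is estimated, between 900 nM and 5800 nM.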

Compound 4, half-maximal inhibitory concentration: 2300 nM
Beside the measured number, compound 4's estimate shows no gap at the digits printed, and the stated range covers the measured number.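

In this assay, methyl in place of hydrogen, here phenyl to 4-methylphenyl, gives a 1.8-fold higher number from compound 3 to compound 4 (0.26 log units; within the scatter), and this step does not differ from the earlier one on the other core: the same change on two cores in this assay, a 2.4-fold higher number (0.38 log units; beyond the scatter) from compound 2 to compound 1 and a 1.8-fold higher number (0.26 log units; within the scatter) from compound 3 to compound 4, 1.3-fold (0.12 log units) apart, within the scatter of two such steps. The change therefore carries across these two cores in this assay, with a similar size of step on each. Within the data shown here, it rests on only two pairs, however, and does not show that the step would hold on other cores, nor does it separate the effect of where the methyl sits, since in compound 4 it is para to a large group and in compound 1 it is not.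

The compounds shown leave open how an amine, a methoxy group or a carboxylic acid at that place on the phenyl would read in this assay. They also leave open whether a longer chain such as ethyl would follow the methyl steps.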